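A Tolyl Group Gives Way to a Thienyl Group

The source may hold more compounds than are shown below. What is called first, only, known or untested is meant among the compounds shown, and "the series" means these compounds.

Compound 3 `Cc1ccc(-c2nc3c(c(-c4ccccc4)nn3-c3ccccc3)c(-c3ccc(O)cc3)c2C#N)cc1` stands second highest of the three numbers in a functional assay on MV4-11 cells (Homo sapiens) for antiproliferative activity, read by resazurin assay, with a stated time of 72 h (a higher number here means a weaker inhibitor, a lower number a stronger inhibitor), where compound 3 gives 3300 nM. Compound 1 `COc1ccc(-c2nc3c(c(-c4ccccc4)nn3-c3ccccc3)c(-c3ccc(O)cc3)c2C#N)cc1` gives 1600 nM, and compound 2 `COc1cc(-c2c(C#N)c(-c3ccco3)nc3c2c(-c2ccccc2)nn3-c2ccccc2)ccc1O` gives 35300 nM. Within the data shown here, the only single-place step among them is a 2.1-fold higher number from compound 1 to compound 3 (0.31 log units; beyond the scatter). Compound 4 `N#Cc1c(-c2cccs2)nc2c(c(-c3ccccc3)nn2-c2ccccc2)c1-c1ccc(O)cc1` differs from compound 3 by thiophen-2-yl in place of 4-methylphenyl on an aromatic carbon. Among the measured compounds shown here, no measured step exchanges a six-membered ring for a five-membered heteroaromatic ring at this place; compound 2 carries a furan-2-yl group there together with a second change, and its value stands far above that of compound 3. On that basis compound 4 is expected to give a higher number than compound 3, a step of a 3.0-fold higher number from compound 3 to compound 4 (0.48 log units; beyond the scatter). The estimate for compound 4 is 10000 nM, ranging from 3000 nM to 40000 nM.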

Compound 4, half-maximal inhibitory concentration: 34200 nM
Compound 4: middle estimate off by 3.4-fold (0.53 log units), on the low side; the range from low to high includes it.
By their numbers in this assay, from the lowest: compound 1; then compound 3; then compounds 4 and 2 (each within the scatter of the next).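

Thiophen-2-yl in place of 4-methylphenyl gives a 10-fold higher number from compound 3 to compound 4 (1.02 log units; beyond the scatter), and in place of 4-methoxyphenyl it gives a 21-fold higher number from compound 1 to compound 4 (1.33 log units; beyond the scatter). At this carbon next to the ring nitrogen, exchanging the six-membered ring for a five-membered one thus produces large steps in this assay, whereas changing only the substituent on the six-membered ring produced a modest one. Nothing available accounts for this loss.

The compounds shown do not separate the effect of the sulfur from that of the smaller ring. They also leave open how an unsubstituted phenyl, a pyridine ring or an amine would fare at this carbon.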